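A few compounds are considered here, and "the series" means these few. Any claim that something is new, unique, unknown or untested is made for them only; others in the source may bear on it.

Compound 1, `CC1CCN(c2c(S(=O)(=O)c3cccc(Cl)c3)cnc3ccc(Cl)cc23)CC1`: in an assay on isolated protein for displacement of a labelled ligand from metabotropic glutamate receptor 5 (Homo sapiens), with a stated time of 60 min, tested at 1 uM (on this read-out lower numbers stand for less inhibition and higher numbers for more inhibition at the one concentration tested (going by the name of the read-out)), compound 1 gives 92%.
Compound 2, `CC1CCN(c2c(S(=O)(=O)c3ccc(Cl)c(Cl)c3)cnc3ccc(Cl)cc23)CC1`: in this assay compound 2 gives 86%.

Compound 2 has the lower of the two numbers, and its nearest neighbour is compound 1, separated from it by a step that stays within the scatter, so the two are read as equivalent. The next compound, compound 3, is `Cc1ccc(S(=O)(=O)c2cnc3ccc(Cl)cc3c2N2CCC(C)CC2)cc1`; its structure differs from compound 2 by 4-methylphenyl in place of 3,4-dichlorophenyl on a sulfonyl sulfur. Among the compounds with values here, the only measured step that touches this region is a number 6 percentage points lower from compound 1 to compound 2 (within the scatter), which showed no change beyond the scatter. That step concerns a single chlorine, whereas here both chlorines leave and a methyl enters, so it bears on the change only loosely. No step beyond the scatter is anticipated. Compound 3 is therefore expected to give about 80%, within a range of 60% to 95%. That estimate corresponds to an expected step of a number 6 percentage points lower from compound 2 to compound 3 (within the scatter).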

Compound 3, a percentage reported as inhibition, at one concentration (the size of the read-out at that concentration, not a potency): 95%
For compound 3 the middle estimate is 15 percentage points below the measured one, and the stated range covers the measured number.
By their numbers in this assay, from the lowest: compounds 2, 1 and 3 (each within the scatter of the next).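

In this assay, 4-methylphenyl in place of 3,4-dichlorophenyl on a sulfonyl sulfur gives a number 9 percentage points higher from compound 2 to compound 3 (within the scatter), and 4-methylphenyl in place of 3-chlorophenyl gives a number 3 percentage points higher from compound 1 to compound 3 (within the scatter). Compounds 1 and 2 both carry chlorine on this aryl group, whereas compound 3 shows that an aryl group with a methyl and no chlorine can stand here without a change beyond the scatter, so all three compounds read as equivalent at the one concentration tested. Nothing measured explains this equivalence.

The compounds shown leave open whether the sulfonyl sulfur would keep this read-out with a phenyl group carrying a carboxylic acid or an amine, or with a cyclohexyl group in place of the aromatic ring. They also leave open whether the three equivalent compounds would separate in a full concentration series.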